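The compounds below may be only part of what the source reports. "The series", "measured", "known", "first", "only" and "open" are said of these compounds alone.

Measured so far:
compound 1 `COc1cccc(Nc2nc(F)nc3[nH]cnc23)c1` — 19000 nM
compound 2 `Oc1ccc(Nc2nc(Cl)nc3[nH]cnc23)cc1` — 16500 nM
compound 3 `COc1ccccc1Nc1nc(Cl)nc2[nH]cnc12` — 33000 nM

The three compounds share a core and differ in the halogen on it and in the group on the aniline ring. In an assay for activation of histidine kinase 3 (Arabidopsis thaliana), read by a beta-galactosidase reporter (a lower number here means that less compound is needed, a higher number that more compound is needed for the effect), compound 1 gives 19000 nM, compound 2 gives 16500 nM and compound 3 gives 33000 nM. Compound 2 carries the lowest of the three numbers, yet its gaps to compound 1 and to compound 3 both fall inside the scatter of repeated measurements, so the three cannot be ranked against one another.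

Compound 4 `COc1ccc(Nc2nc(Cl)nc3[nH]cnc23)cc1` has not been measured. It differs from compound 2 by methyl in place of hydrogen on an oxygen on an aromatic ring; read one bond further out, the change is hydroxy to methoxy. For the measured compounds named here, no measured pair shows this exact step. Compound 1 and compound 3 each carry a methoxy group and sit close to compound 2 in this assay, which gives no sign that a methoxy group moves the number far in either direction. The step expected for compound 4 is therefore small, with no direction claimed beyond the scatter, as a 1.2-fold higher number from compound 2 to compound 4 (0.08 log units; within the scatter). Compound 4 is estimated to give 20000 nM in this assay, within a range from 8000 nM to 50000 nM.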

Compound 4, half-maximal effective concentration: 33100 nM
Estimate against measurement, compound 4: 1.7-fold (0.22 log units) below, within the range that was stated.
By their numbers in this assay, from the lowest: compounds 2, 1, 3 and 4 (each within the scatter of the next).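

In this assay, for the compounds shown here, the change from hydroxy to methoxy, on an oxygen on an aromatic ring, gives the first step between two compounds that differ in one place: a 2.0-fold higher number from compound 2 to compound 4 (0.30 log units; within the scatter), which does not go beyond the scatter. Until now the methoxy compounds could be set beside compound 2 only with other differences in play, whereas this pair isolates the methyl in place of hydrogen and shows no change that can be told from repeat variation, so the hydrogen on that oxygen is not shown to matter for the number in this assay. Nothing measured here gives a reason for the size of this step.

What the compounds shown leave open is whether anything else on this oxygen would move the number beyond the scatter, such as a longer chain like ethoxy, or whether an amine or a carboxylic acid in place of the hydroxy would do so. Going by these compounds alone, no pair isolates the halogen on the shared core either, so fluorine against chlorine, or a bromine there, stays unread.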